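Notes on the carbonyl substituent in a shared anilide series

The source may hold more compounds than are shown below. What is called first, only, known or untested is meant among the compounds shown, and "the series" means these compounds.

Three compounds sharing one core and differing only at the carbonyl carbon have been measured in a functional assay on MGC-803 cells (Homo sapiens) for inhibition, read by MTT assay, with a stated time of 48 h; on this read-out lower numbers stand for stronger inhibition and higher numbers for weaker inhibition. Compound 1 `C#CC(=O)N(Cc1ccc(OC)c(O)c1)c1cc(OC)c(OC)c(OC)c1` gives 170 nM; compound 2 `C=C(C)C(=O)N(Cc1ccc(OC)c(O)c1)c1cc(OC)c(OC)c(OC)c1` gives 390 nM; compound 3 `COc1ccc(CN(C(=O)/C=C/CBr)c2cc(OC)c(OC)c(OC)c2)cc1O` gives 71 nM. Compound 3 stands lowest of the three: the step of a 2.4-fold lower number from compound 1 to compound 3 (0.38 log units; beyond the scatter) and the step of a 5.5-fold lower number from compound 2 to compound 3 (0.74 log units; beyond the scatter) both lie beyond the scatter, and the step of a 2.3-fold higher number from compound 1 to compound 2 (0.36 log units; beyond the scatter) shows the two other groups also separated.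

Compound 4 `COCC(=O)N(Cc1ccc(OC)c(O)c1)c1cc(OC)c(OC)c(OC)c1` is not yet measured. The change from compound 3 is methoxymethyl in place of 3-bromoprop-1-en-1-yl on a carbonyl carbon. All three measured steps concern this same carbonyl carbon and were modest, the largest being a 5.5-fold lower number from compound 2 to compound 3 (0.74 log units; beyond the scatter). Among the measured compounds shown here, none of the measured compounds, however, carries a group without a double or triple bond at this position, so the measured steps give no direct anchor for methoxymethyl. Compound 4 is therefore expected to move away from the lowest number of the set, towards or past the range spanned by compound 1 and compound 2, with the step of an 8.5-fold higher number from compound 3 to compound 4 (0.93 log units; beyond the scatter) expected in the direction of a higher number. The estimate for compound 4 in this assay is 600 nM, with a range from 150 nM to 3000 nM.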

Compound 4, half-maximal inhibitory concentration: 79 nM
Beside the measured number, compound 4's estimate is 7.6-fold (0.88 log units) above it, and the stated range ends above it.
By their numbers in this assay, from the lowest: compounds 3 and 4 (each within the scatter of the next); then compound 1; then compound 2.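

In this assay, replacing 3-bromoprop-1-en-1-yl with methoxymethyl on the carbonyl carbon gives a 1.1-fold higher number from compound 3 to compound 4 (0.05 log units; within the scatter) and so shows that neither the bromine nor a double bond in this substituent is required for a number in this range, at least on the shared core. Methoxymethyl also separates from both other groups, with a 4.9-fold lower number from compound 2 to compound 4 (0.69 log units; beyond the scatter) and a 2.2-fold lower number from compound 1 to compound 4 (0.33 log units; beyond the scatter) on record, so the presence of a double or triple bond does not by itself mark the better groups among these four compounds, and of the three groups carrying one, only 3-bromoprop-1-en-1-yl matches methoxymethyl here. Nothing at hand accounts for this result.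

Still open, from the compounds shown here alone, is whether an ethyl group, which lacks the oxygen of methoxymethyl, or a longer chain such as 2-methoxyethyl, or an amine such as dimethylaminomethyl, would stay level with compound 3 and compound 4 or drift towards compound 2. Also open, going by these compounds, is whether compound 3 and compound 4, so close in this cell read-out, act on the cells in the same way, which a single read-out of this kind cannot separate.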